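From 4-nitrophenyl to 2-nitrophenyl: an expected step

This account rests on a few compounds, and the source may have more. Where it says the series, first, only, none or still open, it means among the compounds named here.

Measured so far in a functional assay on MCF7 cells (Homo sapiens) for antiproliferative activity, read by MTT assay, with a stated time of 72 h (a higher number here means a weaker inhibitor, a lower number a stronger inhibitor), are:
Compound 1 `Nc1nc(N)c2cc(CSC(=S)N3CCN(c4ccc(Cl)cc4)CC3)ccc2n1` at 4880 nM
Compound 2 `Nc1nc(N)c2cc(CSC(=S)N3CCN(c4ccc([N+](=O)[O-])cc4)CC3)ccc2n1` at 1470 nM

Compound 2 holds the lower of the two numbers at 1470 nM and is the stronger inhibitor of the pair. Compound 3 `Nc1nc(N)c2cc(CSC(=S)N3CCN(c4ccccc4[N+](=O)[O-])CC3)ccc2n1` has not yet been measured. Its change from compound 2 is 2-nitrophenyl in place of 4-nitrophenyl on an amine nitrogen in a ring with the same atoms joined differently, as 2-nitrophenyl in place of 4-nitrophenyl on an amine nitrogen in a ring. Among the measured compounds shown here, the only measured step is a 3.3-fold lower number from compound 1 to compound 2 (0.52 log units; beyond the scatter) for nitro in place of chloro on an aromatic carbon. That step exchanged a group and moved none, so it offers a scale but no firm direction. For the measured compounds named here, a step of similar modest size is expected in this assay and tentatively towards a higher number because compound 2 at 1470 nM is the lowest number known so far. The expected change is a 2.2-fold higher number from compound 2 to compound 3 (0.34 log units; beyond the scatter) as an estimate. Compound 3 is expected at 3200 nM within an estimated range from 1000 nM to 9000 nM on present evidence.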

Compound 3, half-maximal inhibitory concentration: 4350 nM
Compound 3: the middle estimate sits 1.4-fold (0.13 log units) below what was measured; the range from low to high includes it.
By their numbers in this assay, from the lowest: compound 2; then compounds 3 and 1 (each within the scatter of the next).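

Moving the nitro group matters in this assay: 2-nitrophenyl in place of 4-nitrophenyl on the amine nitrogen in the ring gives a 3.0-fold higher number from compound 2 to compound 3 (0.47 log units; beyond the scatter) and so shows that where the nitro group sits on the phenyl ring counts, not only that it is present. Set against 4-chlorophenyl, 2-nitrophenyl shows a 1.1-fold lower number from compound 1 to compound 3 (0.05 log units; within the scatter) so among these three compounds the lower number for nitro over chloro appears only with 4-nitrophenyl. No measurement at hand explains why the position of the nitro group changes the number.

As far as these compounds go, whether chloro responds to a change of position as nitro does remains open. So does whether a methoxy group or an amine on that phenyl ring would follow the result for nitro or for chloro.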